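Phenyl in Place of Thiophene on a Weakly Active Nucleoside

The source may hold more compounds than are shown below. What is called first, only, known or untested is meant among the compounds shown, and "the series" means these compounds.

Measured compounds:
Compound 1, `O=c1[nH]cnc2c1c(-c1cccs1)cn2[C@@H]1O[C@H](CO)[C@@H](O)[C@H]1O`. In a functional assay on CCRF-CEM cells (Homo sapiens), read by MTT assay, with a stated time of 72 h (on this read-out higher numbers stand for weaker inhibition and lower numbers for stronger inhibition), compound 1 gives > 20000 nM, which is a limit of the assay and not a number.
Compound 2, `Nc1nc2c(c(-c3cccs3)cn2[C@@H]2O[C@H](CO)[C@@H](O)[C@H]2O)c(=O)[nH]1`. In this assay compound 2 gives > 20000 nM, again only a limit.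
Compound 3, `Nc1nc2c(c(-c3ccoc3)cn2[C@@H]2O[C@H](CO)[C@@H](O)[C@H]2O)c(=O)[nH]1`. In this assay compound 3 gives 17900 nM.

Compound 1 therefore stands only at a limit, and it is not alone there: the limit of > 20000 nM in this assay, at which 2 of the 3 values shown sit. The first step, a step that the two limits leave unreadable from compound 1 to compound 2, cannot be read, since both ends are limits. The second step, an at least 1.1-fold lower number from compound 2 to compound 3 (0.04 log units; that floor lies within the scatter), is the one that bears on the present question, as it too swaps one five-membered aromatic ring for another aromatic ring at the same place on the shared core and produced no change beyond the scatter.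

The unmeasured compound 4 is `O=c1[nH]cnc2c1c(-c1ccccc1)cn2[C@@H]1O[C@H](CO)[C@@H](O)[C@H]1O`. The change from compound 1 is phenyl in place of thiophen-2-yl on an aromatic carbon. By analogy with the step from compound 2 to compound 3, the expected step is a number no higher from compound 1 to compound 4 (the limit leaves the size open), meaning no clear movement in this assay. Compound 4 is therefore estimated at 20000 nM, with a range from 9000 nM to 45000 nM, and a real chance that only a limit is reported again.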

Compound 4, half-maximal inhibitory concentration: > 100000 nM
Compound 4 ended at the assay's limit; the forecaster's own chance of this, stated with the estimate: 60%; at least 5.0-fold (0.69 log units) between middle value and limit.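

Compound 1 and compound 4 each stop at a limit in this assay, not at a number, so the step between them cannot be read. The compounds shown leave open whether phenyl or thiophen-2-yl on the shared core gives stronger inhibition, and what real value either compound has.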